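A few compounds are considered here, and "the series" means these few. Any claim that something is new, unique, unknown or untested is made for them only; others in the source may bear on it.

In a functional assay on MGC-803 cells (Homo sapiens) for cytotoxicity, read by MTT assay, with a stated time of 72 h (on this read-out lower numbers stand for stronger inhibition and higher numbers for weaker inhibition), compound 1 `O=C1C(=Cc2ccc(Br)cc2)C(=O)N(c2ccc(Cl)cc2)N1c1ccc(Cl)cc1` gives 16900 nM. Compound 2 `COc1cccc(C=C2C(=O)N(c3ccc(Cl)cc3)N(c3ccc(Cl)cc3)C2=O)c1O` gives 24300 nM, and a 1.4-fold higher number from compound 1 to compound 2 (0.16 log units; within the scatter) leaves the pair level. Compound 3 `O=C1C(=Cc2ccc(Cl)cc2Cl)C(=O)N(c2ccc(Cl)cc2)N1c1ccc(Cl)cc1` gives > 128000 nM, which is a limit of this assay and not a number. As far as these compounds go, its steps from the other two mark compound 3 as the weakest of the three, and its exact position remains unknown.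

Compound 4 `O=C1C(=C/C=C/c2ccccc2)C(=O)N(c2ccc(Cl)cc2)N1c1ccc(Cl)cc1` carries 2-phenylethenyl in place of 2,4-dichlorophenyl on a double-bonded chain carbon bound to a double-bonded ring carbon. The group that enters has 1 double bond outside aromatic rings, and the chlorine atoms leave with the old group.

Two measured steps at this same place bear on the change: an at least 7.5-fold higher number from compound 1 to compound 3 (0.87 log units; beyond the scatter) and an at least 5.2-fold higher number from compound 2 to compound 3 (0.72 log units; beyond the scatter). Both are beyond the scatter, and read in reverse they show a lower number whenever 2,4-dichlorophenyl is absent, though only in these two cases. Within the data shown here, no measured compound carries 2-phenylethenyl, so the transfer is uncertain, and a second limit reading remains possible. A lower number than the limit of compound 3 is expected in this assay, with compound 4 landing nearer compound 1 and compound 2. The estimated step is an at least 4.2-fold lower number from compound 3 to compound 4 (0.63 log units; beyond the scatter). For compound 4 the estimated value is 30000 nM, with an expected range of 9000 nM to 100000 nM.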

Compound 4, half-maximal inhibitory concentration: 5100 nM
The estimate for compound 4 lay 5.9-fold (0.77 log units) above the measured number; the whole stated range lies above it.
By their numbers in this assay, from the lowest: compound 4; then compounds 1 and 2 (each within the scatter of the next). At a limit, above all of these: compound 3.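

In this assay, 2-phenylethenyl on a double-bonded chain carbon bound to a double-bonded ring carbon gives the lowest number of the four compounds (a 4.8-fold lower number from compound 2 to compound 4 (0.68 log units; beyond the scatter); a 3.3-fold lower number from compound 1 to compound 4 (0.52 log units; beyond the scatter)), so the level of compound 1 and compound 2 is not the lower end for this position. The change from 2,4-dichlorophenyl to 2-phenylethenyl keeps one six-membered aromatic ring of carbon only and the heavy-atom count, yet it produces the widest step in the series (an at least 25-fold lower number from compound 3 to compound 4 (1.39 log units; beyond the scatter)), which shows that this place responds strongly even when that ring and that count stay the same. The reading for compound 3 remains a limit and not a number, so the true size of this step stays open: the limit of > 128000 nM in this assay, at which 1 of the 4 values shown sits.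

The compounds shown do not tell whether the lower number of compound 4 goes with the double bond outside aromatic rings or with the loss of the chlorine atoms, and a plain phenyl or a saturated 2-phenylethyl chain at this place would bear on that. Also open, as far as these compounds go, is how an amine or a carboxylic acid on the ring of 2-phenylethenyl, or a longer chain with further double bonds, would read in this assay.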